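The compounds below may be only part of what the source reports. "The series", "measured", "known", "first", "only" and "open" are said of these compounds alone.

Compound 1 `COc1ccc(-n2cc(NC(=O)c3cccc(NS(=O)(=O)c4ccccc4)c3)cn2)cc1` gives 42200 nM in a functional assay on HeLa cells (Homo sapiens) for inhibition, read by MTT assay, with a stated time of 48 h; on this read-out lower numbers stand for stronger inhibition and higher numbers for weaker inhibition. Compound 2 `COc1cccc(-n2cc(NC(=O)c3cccc(NS(=O)(=O)c4ccccc4)c3)cn2)c1` carries the change 3-methoxyphenyl in place of 4-methoxyphenyl on an aromatic nitrogen and in this assay compound 2 gives 26200 nM, a step described as a 1.6-fold lower number from compound 1 to compound 2 (0.21 log units; within the scatter). Compound 3 `COc1ccc(-n2cc(NC(=O)c3ccc(NS(=O)(=O)c4ccccc4)cc3)cn2)cc1` has a core whose difference from that of compound 1 is not broken down here; in this assay compound 3 gives 47200 nM, which stands within the scatter of compound 1 and compound 2. Compound 4 `COc1cccc(-n2cc(NC(=O)c3ccc(NS(=O)(=O)c4ccccc4)cc3)cn2)c1` is related to compound 3 by 3-methoxyphenyl in place of 4-methoxyphenyl on an aromatic nitrogen, the same change as between compound 1 and compound 2, made at the same place. The step from compound 3 to compound 4 is expected to be a 1.5-fold lower number from compound 3 to compound 4 (0.17 log units; within the scatter), resting on the measured step of a 1.6-fold lower number from compound 1 to compound 2 (0.21 log units; within the scatter). Compound 4 is therefore estimated at 32000 nM, with a likely range from 15000 nM to 70000 nM.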

Compound 4, half-maximal inhibitory concentration: 66200 nM
The estimate for compound 4 lay 2.1-fold (0.32 log units) below the measured number, and the stated range covers the measured number.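

With 3-methoxyphenyl in place of 4-methoxyphenyl on the aromatic nitrogen, the core of compound 3 gives a 1.4-fold higher number from compound 3 to compound 4 (0.15 log units; within the scatter) in this assay. Set beside the earlier step on the core of compound 1, neither step nor the gap between them leaves the usual scatter: the same change on two cores in this assay, a 1.6-fold lower number (0.21 log units; within the scatter) from compound 1 to compound 2 and a 1.4-fold higher number (0.15 log units; within the scatter) from compound 3 to compound 4, 2.3-fold (0.35 log units) apart, within the scatter of two such steps This gives no sign that the change behaves differently on the two cores, but it does not show that the change carries over either, as neither step can be told from no effect at all.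

The compounds shown leave open whether any change at this place moves the number beyond the scatter. Going by these compounds, an amine or a carboxylic acid in place of the methoxy group remains untested here.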